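Pyridyl amide isomers in the trifluoromethyl aniline series

The source may hold more compounds than are shown below. What is called first, only, known or untested is meant among the compounds shown, and "the series" means these compounds.

Compound 1 `CCCNc1cc(NC(=O)c2cccs2)cc(C(F)(F)F)c1` gives 390 nM in an assay on HEK293-TREx cells for antagonist activity at transient receptor potential cation channel subfamily A member 1 (Homo sapiens), read by calcium flux; on this read-out lower numbers stand for stronger inhibition and higher numbers for weaker inhibition. Compound 2 `CCCNc1cc(NC(=O)c2ccccn2)cc(C(F)(F)F)c1` reaches only the limit of > 32000 nM in this assay, so no number is known for it. The step of an at least 82-fold higher number from compound 1 to compound 2 (1.91 log units; beyond the scatter) records this loss, and compound 2 sits at the limit of > 32000 nM in this assay, at which 1 of the 2 values shown sits. Compound 3 `CCCNc1cc(NC(=O)c2cccnc2)cc(C(F)(F)F)c1` differs from compound 2 by pyridin-3-yl in place of pyridin-2-yl on a carbonyl carbon. For the measured compounds named here, no measured step covers this change; the single step known, an at least 82-fold higher number from compound 1 to compound 2 (1.91 log units; beyond the scatter), only sets compound 2 as the floor. Compound 3 is therefore estimated at 8000 nM, within 1500 nM to 32000 nM, an expected gain of an at least 4.0-fold lower number from compound 2 to compound 3 (0.60 log units; beyond the scatter) in this assay, with a real chance that again only a limit is reported.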

Compound 3, half-maximal inhibitory concentration: 940 nM
Estimate against measurement, compound 3: 8.5-fold (0.93 log units) above, outside the stated range (below it).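

Moving the ring nitrogen alone, with the same atoms joined differently, separates an inactive amide from an active one in this assay: an at least 34-fold lower number from compound 2 to compound 3 (1.53 log units; beyond the scatter). The value of compound 2 is a limit and not a number: the limit of > 32000 nM in this assay, at which 1 of the 3 values shown sits. A pyridine ring on the carbonyl carbon is thus compatible with activity, as pyridin-3-yl shows only a modest loss against thiophen-2-yl: a 2.4-fold higher number from compound 1 to compound 3 (0.38 log units; beyond the scatter).

Open, from the compounds shown here alone, is how pyridin-4-yl behaves on the same carbonyl carbon. Also open, going by these compounds, is whether a phenyl or furan-2-yl ring could match thiophen-2-yl here.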